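This account rests on a few compounds, and the source may have more. Where it says the series, first, only, none or still open, it means among the compounds named here.

Compound 1 `CCCN(CCC)c1nc(C(F)(F)F)ccc1CNC(=O)Nc1cccc2[nH]c(=O)ccc12`: 5.21 nM in an assay on HEK cells for antagonist activity at transient receptor potential cation channel subfamily V member 1 (Homo sapiens), read by FLIPR; a higher number here means a weaker inhibitor, a lower number a stronger inhibitor
Compound 2 `CCCCOc1nc(C(F)(F)F)ccc1CNC(=O)Nc1cccc2[nH]c(=O)ccc12`: 4 nM in this assay
Compound 3 `CCCCCCOc1nc(C(F)(F)F)ccc1CNC(=O)Nc1cccc2[nH]c(=O)ccc12`: 3.19 nM in this assay

The three numbers sit close together. Compound 3 has the smallest of them, yet the steps of a 1.6-fold lower number from compound 1 to compound 3 (0.21 log units; within the scatter) and a 1.3-fold lower number from compound 2 to compound 3 (0.10 log units; within the scatter) both fall within the usual scatter, so none of the three can be called a stronger or weaker inhibitor than another. The step of a 1.3-fold lower number from compound 1 to compound 2 (0.11 log units; within the scatter) shows the same picture for the exchange of the amine for the ether.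

Compound 4 `O=C(NCc1ccc(C(F)(F)F)nc1OCC1CCC1)Nc1cccc2[nH]c(=O)ccc12` differs from compound 3 in one place: cyclobutyl in place of pentyl on a saturated chain carbon bound to an oxygen on an aromatic ring. Among the measured compounds shown here, the only measured step that touches the chain beyond the oxygen is a 1.3-fold lower number from compound 2 to compound 3 (0.10 log units; within the scatter), where lengthening the chain left the number essentially where it was. Shortening it and closing it into a four-membered ring has no measured parallel here, so the expectation rests on that single step and on the general flatness of the three values. The expected step is a 1.3-fold higher number from compound 3 to compound 4 (0.10 log units; within the scatter), that is, nothing beyond the scatter in this assay in either direction. Compound 4 is therefore estimated at 4 nM, with a plausible range from 1.5 nM to 11 nM.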

Compound 4, half-maximal inhibitory concentration: 1.49 nM
Estimate against measurement, compound 4: 2.7-fold (0.43 log units) above; the measured number lies below the stated range.
By their numbers in this assay, from the lowest: compound 4; then compounds 3, 2 and 1 (each within the scatter of the next).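

Cyclobutyl on the saturated chain carbon bound to an oxygen on an aromatic ring gives the first changes in this series that lie beyond the scatter in this assay (a 2.1-fold lower number from compound 3 to compound 4 (0.33 log units; beyond the scatter) and a 2.7-fold lower number from compound 2 to compound 4 (0.43 log units; beyond the scatter)), whereas the open chains of compounds 2 and 3 could not be told apart. Exchanging dipropylamino for an ether oxygen carrying an open chain did not separate compounds 2 and 3 from compound 1, but cyclobutylmethoxy in place of dipropylamino does (a 3.5-fold lower number from compound 1 to compound 4 (0.54 log units; beyond the scatter)), so compound 4 is the strongest inhibitor of the four, though all three steps are modest. Nothing available explains why this group lowers the number.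

Going by these compounds, with a single ring-bearing compound, it remains open whether the ring itself matters or whether a branched open chain such as isobutyl would serve equally well, and whether a cyclopropyl or cyclohexyl ring would do better or worse in the same place. On these data alone, it is also open whether the ether oxygen is needed, which a cyclobutylmethylamino group at that aromatic carbon could test.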